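Plasma protein binding in a benzoxazolone propanoic acid series

The compounds below may be only part of what the source reports. "The series", "measured", "known", "first", "only" and "open" are said of these compounds alone.

Measured so far:
compound 1 `CCOc1cc2oc(=O)n(CCC(=O)O)c2cc1Cl` gives 95.8%
compound 2 `CCc1cc2oc(=O)n(CCC(=O)O)c2cc1Cl` gives 98.7%
compound 3 `O=C(O)CCn1c(=O)oc2cc(OCC3CC3)c(Cl)cc21` gives 96%

All three values come from an ADME assay on a cell-free system (plasma, Homo sapiens) for protein binding. Compound 3 stands second highest of the three unbound fractions. Its nearest neighbour is compound 1: a 1.1-fold lower unbound fraction from compound 1 to compound 3 (0.02 log units; within the scatter). Among the measured compounds shown here, the one step in this set that clears the scatter runs from compound 1 to compound 2, a 3.2-fold lower unbound fraction from compound 1 to compound 2 (0.51 log units; beyond the scatter), and the same gap shows the other way round as a 3.1-fold higher unbound fraction from compound 2 to compound 3 (0.49 log units; beyond the scatter).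

The next compound, compound 4 `O=C(O)CCn1c(=O)oc2cc(Cl)c(Cl)cc21`, differs from compound 3 in one place: chloro in place of cyclopropylmethoxy on an aromatic carbon. For the measured compounds named here, no measured step swaps an oxygen-bearing group for a chloro, so the nearest guide is the step from compound 1 to compound 2, in which an alkyl without an acceptor replaced an alkoxy and the unbound fraction fell modestly. Chloro likewise carries no acceptor, so a move in the same direction, smaller or similar in size, is expected in this assay rather than none at all, with compound 2 marking the high end seen so far.

For compound 4 the expected step is a 1.6-fold lower unbound fraction from compound 3 to compound 4 (0.20 log units; within the scatter), and the expected value is 97.5%, within a range of 95.5% to 98.8%.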

Compound 4, plasma protein binding in the plasma assay: 98.2%
For compound 4 the middle estimate is 1.4-fold (0.14 log units) (unbound fraction) above the measured one; measured number inside the range.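

Chloro on this aromatic carbon, ortho to a chloro group, shows that a single chlorine atom lands with ethyl rather than with the oxygen-linked groups in the plasma assay: a 2.2-fold lower unbound fraction from compound 3 to compound 4 (0.35 log units; beyond the scatter) and a 2.3-fold lower unbound fraction from compound 1 to compound 4 (0.37 log units; beyond the scatter), but a 1.4-fold higher unbound fraction from compound 2 to compound 4 (0.14 log units; within the scatter). Across these four compounds, ethoxy and cyclopropylmethoxy therefore stand apart from ethyl and chloro, no compound goes against this split, and the position tolerates a change from five heavy atoms to one without taking the unbound fraction past the level seen with ethyl. In a physicochemical assay for pharmacokinetics, at pH 6 (a lower number here means that the compound disappears faster, a higher number that the compound lasts longer), compound 3 gives > 1000 h, which is a limit of the assay and not a number: the limit of > 1000 h in the physicochemical assay, at which 1 of the 2 values shown sits. In the physicochemical assay compound 4 gives 334 h, so this change also registers in the half-life, with an at least 2.9-fold lower number from compound 3 to compound 4 (0.47 log units; beyond the scatter).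

From the compounds shown here alone, it remains open whether an amine or a longer alkoxy chain on this aromatic carbon would fall with the ethoxy and cyclopropylmethoxy compounds or with the ethyl and chloro compounds in the plasma assay. Going by these compounds, it is also open whether the direction seen in the physicochemical assay for cyclopropylmethoxy and chloro extends to ethoxy and ethyl.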